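Swapping the aryl group on the hydrazone carbon: compound 3

The source may report more compounds than this note shows. Statements on the series, on what has been measured and on what is new or still open speak of the compounds shown alone.

For the measured compounds named here, compound 2 `O=C(COc1cccc2ccccc12)N/N=C/c1cccc(O)c1` is one of two compounds measured in an ADME assay on HEL cells (Homo sapiens) for cytotoxicity; a higher number here means that more compound is tolerated, a lower number that less compound is tolerated. In this assay compound 2 gives 62.7 ug/mL, the lower of the two numbers seen so far, while compound 1 `O=C(COc1cccc2ccccc12)N/N=C/c1ccc(Cl)cc1` gives 100 ug/mL. Going by the values given here, the only step on record, a 1.6-fold lower number from compound 1 to compound 2 (0.20 log units; within the scatter), is an exchange of the aromatic group on the same carbon and stays within the scatter. Compound 3 `O=C(COc1cccc2ccccc12)N/N=C/c1ccccc1Br` differs from compound 2 in just that place: 2-bromophenyl in place of 3-hydroxyphenyl on a carbon with a double bond to nitrogen. Among the compounds with values here, the one step that bears on this change was small, so the change from compound 2 to compound 3 is expected to produce no step in this assay beyond the scatter, in either direction, which as a step reads a 1.3-fold higher number from compound 2 to compound 3 (0.11 log units; within the scatter). On that basis, compound 3 is estimated to give 80 ug/mL in this assay, within a range from 40 ug/mL to 160 ug/mL.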

Compound 3, half-maximal cytotoxic concentration: 100 ug/mL
For compound 3 the middle estimate is 1.3-fold (0.10 log units) below the measured one; the range from low to high includes it.
By their numbers in this assay, from the lowest: compounds 2, 1 and 3 (each within the scatter of the next).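

With a third aryl group at this place, on a carbon with a double bond to nitrogen, this assay still shows no step beyond the scatter: there is a 1.6-fold higher number from compound 2 to compound 3 (0.20 log units; within the scatter), and no change at the digits printed from compound 1 to compound 3 (within the scatter). The count of hydrogen-bond donors and acceptors also differs here: 3-hydroxyphenyl has one of each and 2-bromophenyl has neither, yet the step between them stays within the scatter. No measurement at hand gives a reason for this flat picture.

On these data alone, all three groups are six-membered aromatic rings of carbon only, so it remains open whether an amine, a carboxylic acid or a longer chain at this place would give a step beyond the scatter. Also open, as far as these compounds go, is whether a change elsewhere on the shared core would do so.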